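This account rests on a few compounds, and the source may have more. Where it says the series, first, only, none or still open, it means among the compounds named here.

The measured compounds:
compound 1, `N#Cc1cccc(COc2ccc(-c3cc(CN4CCN(c5ccc(C(F)(F)F)cn5)CC4)no3)cc2)c1`, with 1400 nM in a functional assay on MCF7 cells (Homo sapiens) for antiproliferative activity, read by sulforhodamine B assay, with a stated time of 72 h; on this read-out higher numbers stand for weaker inhibition and lower numbers for stronger inhibition
compound 2, `N#Cc1cccc(COc2ccc(-c3cc(CN4CCN(Cc5cccc(F)c5)CC4)no3)cc2)c1`, with 2400 nM in this assay

Both compounds share one core and differ only in the group attached to an amine nitrogen in a ring. Compound 2 has the highest of the two numbers; its nearest neighbour is compound 1, and the step of a 1.7-fold higher number from compound 1 to compound 2 (0.23 log units; within the scatter) lies within the scatter, so the two cannot be told apart. Compound 3, `N#Cc1cccc(COc2ccc(-c3cc(CN4CCN(C(=O)C5CC5)CC4)no3)cc2)c1`, has not yet been measured. It differs from compound 2 by cyclopropylcarbonyl in place of 3-fluorobenzyl on an amine nitrogen in a ring. Among the measured compounds shown here, only one measured step bears on this change, namely a 1.7-fold higher number from compound 1 to compound 2 (0.23 log units; within the scatter), an exchange of the group on the same ring nitrogen that stayed within the scatter. That exchange did not move the number, and nothing in the data shows this position to be sensitive. The entering group, however, is unlike either group already tried, so the uncertainty is wider. Compound 3 is therefore expected to land close to compound 2, with a 1.3-fold higher number from compound 2 to compound 3 (0.10 log units; within the scatter) expected to stay within the scatter. The estimate for compound 3 in this assay is 3000 nM, with a range from 1000 nM to 9000 nM.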

Compound 3, half-maximal inhibitory concentration: 7600 nM
Estimate against measurement, compound 3: 2.5-fold (0.40 log units) below; measured number inside the range.
By their numbers in this assay, from the lowest: compounds 1 and 2 (each within the scatter of the next); then compound 3.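

In this assay the group on the ring nitrogen turns out to matter: the earlier exchange stayed within the scatter, but cyclopropylcarbonyl in place of 3-fluorobenzyl gives a 3.2-fold higher number from compound 2 to compound 3 (0.50 log units; beyond the scatter) and cyclopropylcarbonyl in place of 5-(trifluoromethyl)pyridin-2-yl gives a 5.4-fold higher number from compound 1 to compound 3 (0.73 log units; beyond the scatter) in this comparison. Both steps are modest, but both run towards weaker inhibition, so this position is not indifferent to what it carries. The entering group differs from the two earlier groups in several ways at once, with a three-membered non-aromatic ring and a carbonyl in place of a six-membered aromatic ring, and nothing available here shows which of these differences accounts for the higher number.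

The compounds shown leave open whether the carbonyl or the cyclopropyl ring goes with the higher number, and an acetyl or benzoyl group on this nitrogen, or a cyclopropylmethyl group without the carbonyl, would help to separate the two. They also leave open whether a plain benzyl group or a simple methyl group would give a number closer to that of compound 2 or to that of compound 3.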